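This account rests on a few compounds, and the source may have more. Where it says the series, first, only, none or still open, it means among the compounds named here.

Of the compounds shown here, three of one series have been measured in an assay on isolated protein for agonist activity at Bile acid receptor (Homo sapiens), read by TR-FRET; a higher number here means that more compound is needed for the effect, a lower number that less compound is needed. Compound 1 `CC(C)c1onc(-c2c(Cl)cccc2Cl)c1COc1ccc(-c2nc3ccc(C(=O)O)cc3n2CC2CC2)cc1` gives 29.1 nM there; compound 2 `CC(C)c1onc(-c2c(Cl)cccc2Cl)c1COc1ccc(-c2nc3ccc(C(=O)O)cc3n2-c2ccc(F)cc2)cc1` gives 15.1 nM; compound 3 `CC(C)c1onc(-c2c(Cl)cccc2Cl)c1COc1ccc(-c2nc3ccc(C(=O)O)cc3n2Cc2ccc(F)cc2)cc1` gives 105 nM. Among these three numbers compound 1 holds the second highest place: compound 2 lies nearest, with a 1.9-fold lower number from compound 1 to compound 2 (0.28 log units; within the scatter), while compound 3 lies furthest, with a 3.6-fold higher number from compound 1 to compound 3 (0.56 log units; beyond the scatter). Between the other two, the step of a 7.0-fold higher number from compound 2 to compound 3 (0.84 log units; beyond the scatter) separates them.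

Compound 4 `CC(C)Cn1c(-c2ccc(OCc3c(-c4c(Cl)cccc4Cl)noc3C(C)C)cc2)nc2ccc(C(=O)O)cc21` has not been measured in this assay. It differs from compound 1 in one place: isopropyl in place of cyclopropyl on a saturated chain carbon bound to an aromatic nitrogen. Within the data shown here, the only measured step at that same place is the one from compound 1 to compound 3, where a 4-fluorophenyl entered on the saturated chain carbon and the number rose by a 3.6-fold higher number from compound 1 to compound 3 (0.56 log units; beyond the scatter). The step from compound 1 to compound 2 changes the group on the aromatic nitrogen entirely and bears less directly. Among the measured compounds shown here, no measured pair exchanges cyclopropyl for isopropyl, so the replacement of one three-membered ring of carbon only by a chain of the same count has no direct precedent here. Compound 4 is therefore expected to stay close to compound 1, with the step of a 1.2-fold higher number from compound 1 to compound 4 (0.08 log units; within the scatter) estimated to fall within the scatter. The estimated value for compound 4 is 35 nM, with a range from 14 nM to 90 nM.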

Compound 4, half-maximal effective concentration: 24.7 nM
Estimate against measurement, compound 4: 1.4-fold (0.15 log units) above; the range from low to high includes it.
By their numbers in this assay, from the lowest: compounds 2, 4 and 1 (each within the scatter of the next); then compound 3.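

In this assay, the exchange of cyclopropyl for isopropyl on the saturated chain carbon bound to an aromatic nitrogen gives a 1.2-fold lower number from compound 1 to compound 4 (0.07 log units; within the scatter), so at this place the three-membered ring can be opened to a chain of the same carbon count with no change that can be told from the scatter. The gap to the benzyl-type compound remains clear, with a 4.3-fold lower number from compound 3 to compound 4 (0.63 log units; beyond the scatter), while the isobutyl of compound 4 cannot be told from the 4-fluorophenyl set directly on the aromatic nitrogen, with a 1.6-fold higher number from compound 2 to compound 4 (0.21 log units; within the scatter), so two quite different groups on that nitrogen give numbers within the scatter of each other. Nothing at hand explains why the ring can be given up here or why the 4-fluorobenzyl group stands apart.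

On these data alone, whether a longer chain, a cyclobutyl ring or an amine on the same saturated chain carbon would keep the number where it stands remains open. So does whether the match between cyclopropyl and isopropyl would hold with any change elsewhere on the shared core.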